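Replacing Chloro with Methylsulfanyl in a Level Series

The source may hold more compounds than are shown below. What is called first, only, known or untested is meant among the compounds shown, and "the series" means these compounds.

In a functional assay on HFF cells (Homo sapiens) for cytotoxicity (a higher number here means a weaker inhibitor, a lower number a stronger inhibitor), compound 3 (`O[C@@H]1[C@@H](CCl)OC(n2c(Cl)nc3cc(Cl)c(Cl)cc32)[C@@H]1O`) gives 32000 nM. Compound 1 (`CC(=O)OC1C(CI)OC(n2c(Cl)nc3cc(Cl)c(Cl)cc32)C1OC(C)=O`) gives 32000 nM, and compound 2 (`CC(=O)OC1C(CN=[N+]=[N-])OC(n2c(Cl)nc3cc(Cl)c(Cl)cc32)C1OC(C)=O`) gives 32000 nM, so all three stand level at the digits shown. Compound 4 (`CSC[C@H]1OC(n2c(Cl)nc3cc(Cl)c(Cl)cc32)[C@H](O)[C@@H]1O`) departs from compound 3 in one place: methylsulfanyl in place of chloro on a saturated chain carbon bound to a saturated ring carbon. Methylsulfanyl stands in place of chloro on a saturated chain carbon bound to a saturated ring carbon.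

Among the measured compounds shown here, only one measured step bears on this change. Azido in place of iodo at that same place gives no change at the digits printed from compound 1 to compound 2 (within the scatter). For the measured compounds named here, this evidence is indirect, since compound 1 and compound 2 differ from compound 3 elsewhere in the shared core, and no methylsulfanyl compound has yet been measured. Even so, nothing in the series points to a shift in either direction. The expected result is no change at the digits printed from compound 3 to compound 4 (within the scatter), with no step beyond the scatter. For compound 4 the estimated value is 32000 nM, with an expected range of 15000 nM to 60000 nM.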

Compound 4, half-maximal inhibitory concentration: 32000 nM
The estimate for compound 4 equals the measured number at the digits printed; measured number inside the range.
By their numbers in this assay, from the lowest: compounds 1, 2, 3 and 4 (each within the scatter of the next).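

In this assay, among the compounds shown here, the first direct reading for the side chain on the free-hydroxyl core gives no change at the digits printed from compound 3 to compound 4 (within the scatter) when methylsulfanyl replaces chloro on a saturated chain carbon bound to a saturated ring carbon. For the compounds shown here, until now the only step at this place was no change at the digits printed from compound 1 to compound 2 (within the scatter), on the acetylated core of compound 1, so the result extends the level picture to a second pair and a second kind of replacement, one that brings in sulfur. No supporting measurement is available to account for this flat response.

What the compounds shown leave open is whether an amine, a carboxylic acid or a longer chain at this place would also stay level. They also leave open whether methylsulfanyl would read the same on the acetylated core.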